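A few compounds are considered here, and "the series" means these few. Any claim that something is new, unique, unknown or untested is made for them only; others in the source may bear on it.

Compound 1 `CCC[C@@H](NC(=O)c1nccs1)c1cnc(Nc2ccc(C)nc2)c(Cl)c1`: 8.2 nM
Compound 2 `Cc1ccc(Nc2ncc([C@H](NC(=O)c3nccs3)C3CCCCC3)cc2Cl)cn1`: 37.8 nM
Compound 3 `C=CC[C@@H](NC(=O)c1nccs1)c1cnc(Nc2ccc(C)nc2)c(Cl)c1`: 2.4 nM

In a functional assay on HEK293 cells for negative allosteric modulation of metabotropic glutamate receptor 5 (Homo sapiens), read by HTRF and inositol phosphate accumulation (a higher number here means a weaker inhibitor, a lower number a stronger inhibitor), compound 1 stands second highest of the three numbers, with compound 3 nearest (a 3.4-fold lower number from compound 1 to compound 3 (0.53 log units; beyond the scatter)) and compound 2 furthest (a 4.6-fold higher number from compound 1 to compound 2 (0.66 log units; beyond the scatter)). Compound 4 `CCC[C@@H](NC(=O)c1nccs1)c1cnc(Nc2cnc(C)s2)c(Cl)c1` differs from compound 1 in one place: 2-methyl-1,3-thiazol-5-yl in place of 6-methylpyridin-3-yl on a nitrogen on an aromatic ring. Among the measured compounds shown here, none of the measured steps touches this part of the shared core; they all alter the saturated chain carbon (a 4.6-fold higher number from compound 1 to compound 2 (0.66 log units; beyond the scatter), a 16-fold lower number from compound 2 to compound 3 (1.20 log units; beyond the scatter)), so they do not bear on the change to compound 4. With no guide from the data, the expectation for compound 4 in this assay is a step of a 1.2-fold higher number from compound 1 to compound 4 (0.09 log units; within the scatter), that is none beyond the scatter, held with wide uncertainty. Compound 4 is therefore estimated at 10 nM, within 3 nM to 35 nM.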

Compound 4, half-maximal inhibitory concentration: 60 nM
Beside the measured number, compound 4's estimate is 6.0-fold (0.78 log units) below it; the whole stated range lies below it.
By their numbers in this assay, from the lowest: compound 3; then compound 1; then compounds 2 and 4 (each within the scatter of the next).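

In this assay, among the compounds shown here, the group on the nitrogen on an aromatic ring proves to matter: 2-methyl-1,3-thiazol-5-yl in place of 6-methylpyridin-3-yl gives a 7.3-fold higher number from compound 1 to compound 4 (0.86 log units; beyond the scatter), whereas the earlier steps changed only the saturated chain carbon. With the propyl chain held fixed, these two methyl-bearing aromatic rings are therefore not interchangeable at this position. No evidence is available to explain the weaker inhibition. On these data alone, it remains open whether the same step holds with the allyl chain of compound 3, and what a plain phenyl or an unmethylated pyridin-3-yl would give here.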